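The source may hold more compounds than are shown below. What is called first, only, known or untested is meant among the compounds shown, and "the series" means these compounds.

The measured compounds:
Compound 1, `COc1cccc(CNCCCNc2ccnc3cc(Oc4ccc(F)cc4)ccc23)c1O`, gives 11000 nM in an ADME assay on HepG2 cells (Homo sapiens) for cytotoxicity, read by luminescence, CellTiter-Glo and ATP content, with a stated time of 72 h; a higher number here means that more compound is needed for the effect, a lower number that less compound is needed.
Compound 2, `COc1cccc(Oc2ccc3c(NCCCNCc4cccc(OC)c4O)ccnc3c2)c1`, gives 5300 nM in this assay.
Compound 3, `COc1cccc(CNCCCNc2ccnc3cc(Cc4ccc(C#N)cc4)ccc23)c1O`, gives 7150 nM in this assay.

Compound 3 stands second highest of these three numbers. Its neighbours lie close on both sides: the step of a 1.3-fold higher number from compound 2 to compound 3 (0.13 log units; within the scatter) is within the scatter, and so is a 1.5-fold lower number from compound 1 to compound 3 (0.19 log units; within the scatter). Among the compounds with values here, the only step beyond the scatter is a 2.1-fold lower number from compound 1 to compound 2 (0.32 log units; beyond the scatter), and it is modest.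

Compound 4, `COc1cccc(CNCCCNc2ccnc3cc(Cc4cccc(C(F)(F)F)c4)ccc23)c1O`, has not yet been measured in this assay. It differs from compound 3 in a single place: 3-(trifluoromethyl)phenyl in place of 4-cyanophenyl on a saturated chain carbon bound to an aromatic carbon. Within the data shown here, the steps that touch the same place, namely a 1.5-fold lower number from compound 1 to compound 3 (0.19 log units; within the scatter) and a 1.3-fold higher number from compound 2 to compound 3 (0.13 log units; within the scatter), both stayed within the scatter, and no measured step involves the entering trifluoromethyl group at all. The account therefore expects no step beyond the scatter, if anything a slightly lower number, for a 1.2-fold lower number from compound 3 to compound 4 (0.08 log units; within the scatter). Compound 4 is estimated at 6000 nM, with a range from 2500 nM to 14000 nM.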

Compound 4, half-maximal effective concentration: 1720 nM
Compound 4: the middle estimate sits 3.5-fold (0.54 log units) above what was measured, and the stated range ends above it.
By their numbers in this assay, from the lowest: compound 4; then compounds 2, 3 and 1 (each within the scatter of the next, the first and the last beyond it).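

At this position on the shared core, the earlier changes had stayed close to the scatter, but exchanging 4-cyanophenyl for 3-(trifluoromethyl)phenyl on the saturated chain carbon gives a 4.2-fold lower number from compound 3 to compound 4 (0.62 log units; beyond the scatter) in this assay, showing that the number does respond to the aromatic group placed here. The 3-(trifluoromethyl)benzyl group also separates clearly from both phenoxy groups, with a 3.1-fold lower number from compound 2 to compound 4 (0.49 log units; beyond the scatter) and a 6.4-fold lower number from compound 1 to compound 4 (0.81 log units; beyond the scatter), leaving compound 4 with the lowest number of the four. Nothing at hand bears on the reason for this drop.

Within the data shown here, the single step changes both the group and its name-given ring position, so it remains open whether the trifluoromethyl group or its placement matters. Going by these compounds, a 3-cyanophenyl or 4-(trifluoromethyl)phenyl group on the same carbon would separate the two, and how an amine or a carboxylic acid on that ring would read also remains open.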